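Linker variation on the oxadiazole amidoxime series

The source may hold more compounds than are shown below. What is called first, only, known or untested is meant among the compounds shown, and "the series" means these compounds.

Measured compounds:
compound 1 `NS(=O)(=O)CC(=O)NCCSc1nonc1/C(=N/O)Nc1ccc(F)c(Br)c1` — 12 nM
compound 2 `CSc1nonc1/C(=N/O)Nc1ccc(F)c(Br)c1` — 15 nM
compound 3 `NS(=O)(=O)NCCOc1nonc1/C(=N/O)Nc1ccc(F)c(Br)c1` — 12 nM

In an assay for inhibition of Indoleamine 2,3-dioxygenase 1 (Homo sapiens), read by fluorescence, with a stated time of 24 h (a higher number here means a weaker inhibitor, a lower number a stronger inhibitor), compound 3 gives 12 nM. It stands level with compound 1 at the digits given, and its gap to compound 2 is within the scatter; none of the three numbers separates from the others.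

Compound 4 `CS(=O)(=O)NCCSc1nonc1/C(=N/O)Nc1ccc(F)c(Br)c1` is not yet measured. It differs from compound 3 by a group of 8 heavy atoms (3 carbon, 1 nitrogen, 2 oxygen, 2 sulfur; no ring) in place of a group of 8 heavy atoms (2 carbon, 2 nitrogen, 3 oxygen, 1 sulfur; no ring), on an aromatic carbon, so the ether-linked sulfamoylamino chain gives way to a thioether-linked methanesulfonamide chain of the same length.

For the measured compounds named here, two measured steps bear on this. The step of a 1.3-fold higher number from compound 1 to compound 2 (0.10 log units; within the scatter) removes the whole thioether-linked chain and leaves the number essentially where it was. The step of a 1.3-fold lower number from compound 2 to compound 3 (0.10 log units; within the scatter) installs the ether-linked sulfamoylamino chain in place of methylsulfanyl, again within the scatter. The chain attached at this ring carbon has therefore made no difference beyond the scatter in any of the three measured compounds, whether absent, short, or long and polar.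

For compound 4 a step of a 1.1-fold higher number from compound 3 to compound 4 (0.03 log units; within the scatter) is expected, that is, no change beyond the scatter. Compound 4 is estimated at 13 nM, with a likely range of 6 nM to 30 nM.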

Compound 4, half-maximal inhibitory concentration: 9.3 nM
For compound 4 the middle estimate is 1.4-fold (0.15 log units) above the measured one; low and high end bracket the measured number.
By their numbers in this assay, from the lowest: compounds 4, 1, 3 and 2 (each within the scatter of the next).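

In this assay, replacing 2-(sulfamoylamino)ethoxy on the aromatic carbon with the thioether-linked methanesulfonamide chain gives a 1.3-fold lower number from compound 3 to compound 4 (0.11 log units; within the scatter), so a chain with a different linking atom, a different end group and a different hydrogen-bond donor count still does not separate from the ether-linked chain. The thioether-linked chains now give two further readings: methylsulfonyl in place of (sulfamoylmethyl)carbonyl on the amine nitrogen gives a 1.3-fold lower number from compound 1 to compound 4 (0.11 log units; within the scatter), and (methanesulfonamido)methyl in place of hydrogen on the saturated chain carbon bound to the sulfur gives a 1.6-fold lower number from compound 2 to compound 4 (0.21 log units; within the scatter), so neither the end group nor the presence of the extended chain moves the number beyond the scatter across these compounds. No measurement available here accounts for this flat response.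

The step from compound 3 to compound 4 alters the linking atom and the chain end together, so the contribution of each stays unresolved. From the compounds shown here alone, whether a chain ending in a primary amine or a carboxylic acid, or a longer chain, would also stay within the scatter remains open.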